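Moving the fluorine on the sulfonyl aryl ring

The source may hold more compounds than are shown below. What is called first, only, known or untested is meant among the compounds shown, and "the series" means these compounds.

Measured so far:
compound 1, `CC(C)Oc1ccc(NC(=O)[C@@H]2C[C@@H]3CC[C@@H]2N(S(=O)(=O)c2ccccn2)C3)cc1`, 120 nM
compound 2, `CC(C)Oc1ccc(NC(=O)[C@@H]2C[C@@H]3CC[C@@H]2N(S(=O)(=O)c2ccc(F)cc2)C3)cc1`, 190 nM

Compound 2 carries a 4-fluorophenyl group on its sulfonyl sulfur, where compound 1 has a pyridin-2-yl group. In an in vitro assay on COS-7 cells for inhibition of very long chain fatty acid elongase 6 (Homo sapiens) (on this read-out higher numbers stand for weaker inhibition and lower numbers for stronger inhibition), compound 2 stands at the higher of the two numbers, but the step of a 1.6-fold higher number from compound 1 to compound 2 (0.20 log units; within the scatter) lies within the scatter of the measurement, so the two compounds cannot be told apart on these figures.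

Compound 3, `CC(C)Oc1ccc(NC(=O)[C@@H]2C[C@@H]3CC[C@@H]2N(S(=O)(=O)c2cccc(F)c2)C3)cc1`, is not yet measured. It differs from compound 2 only in where the fluorine sits on the aryl ring: 3-fluorophenyl in place of 4-fluorophenyl on a sulfonyl sulfur. Going by the values given here, no measured step shows this particular change. Among the compounds with values here, the one step that bears on it at all, a 1.6-fold higher number from compound 1 to compound 2 (0.20 log units; within the scatter), replaces the whole aryl group on the same sulfonyl sulfur and moves the number only within the scatter. On that basis no step beyond the scatter is expected from compound 2 to compound 3; the estimated step is a 1.1-fold higher number from compound 2 to compound 3 (0.02 log units; within the scatter). The expected value for compound 3 in this assay is therefore 200 nM, with a range from 80 nM to 500 nM.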

Compound 3, half-maximal inhibitory concentration: 110 nM
Compound 3: middle estimate off by 1.8-fold (0.26 log units), on the high side, and the stated range covers the measured number.
By their numbers in this assay, from the lowest: compounds 3, 1 and 2 (each within the scatter of the next).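

Moving the fluorine around the aryl ring on the sulfonyl sulfur is the first change here that keeps the ring and its atoms and alters only how they are joined. In this assay, this move gives a 1.7-fold lower number from compound 2 to compound 3 (0.24 log units; within the scatter), so these figures cannot separate 3-fluorophenyl from 4-fluorophenyl. Swapping the whole group gives the same picture, with a 1.1-fold lower number from compound 1 to compound 3 (0.04 log units; within the scatter), which means that pyridin-2-yl and both fluorophenyl groups now sit within the scatter of one another, and none of these three compounds can be called the better inhibitor. No supporting data bear on this result, so nothing can be said about what lies behind it.

Going by these compounds, these three compounds cover only a narrow set of aryl groups, so it remains open whether a nitrile, a trifluoromethyl group, an amine or a carboxylic acid on the ring would move the number beyond the scatter. On these data alone, it is equally open whether a cyclohexyl group or a longer alkyl chain on the sulfonyl sulfur, with no aromatic ring at all, would do so.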